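The compounds below may be only part of what the source reports. "The series", "measured", "known", "first", "only" and "open" are said of these compounds alone.

Working notes on the series. Among the measured compounds shown here, compound 1 `COc1nsnc1C(=O)Nc1cc(C(F)(F)F)cc(C(F)(F)F)c1` is the lower of the two compounds measured so far: in an assay on isolated protein for inhibition of mitogen-activated protein kinase kinase kinase 14 (Homo sapiens), read by ADP-Glo, with a stated time of 60 min, tested at 100 uM, in the presence of a further agent that is not named here (on this read-out higher numbers stand for more inhibition at the one concentration tested (going by the name of the read-out) and lower numbers for less inhibition), compound 1 gives -1.9%, and its nearest neighbour is compound 2 `Cn1nc(O)c(C(=O)Nc2cc(C(F)(F)F)cc(C(F)(F)F)c2)n1`, which in this assay gives 9.1%. For the measured compounds named here, the one measured step, a number 11 percentage points higher from compound 1 to compound 2 (beyond the scatter), swaps a five-membered ring bearing a sulfur for a hydroxy-bearing five-membered ring on the carbonyl carbon.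

Compound 3 `O=C(Nc1cc(C(F)(F)F)cc(C(F)(F)F)c1)c1n[nH]nc1O` is not yet measured. It differs from compound 1 in one place, (a group of 6 heavy atoms (2 carbon, 3 nitrogen, 1 oxygen; one five-membered aromatic ring with 3 hetero atoms) in place of a group of 7 heavy atoms (3 carbon, 2 nitrogen, 1 oxygen, 1 sulfur; one five-membered aromatic ring with 3 hetero atoms), on a carbonyl carbon). The ring leaving is the same as in the step to compound 2, and the ring entering is close in kind to the one entering there, carrying the hydroxy group on a three-hetero-atom five-membered ring; the counts beside each step show the difference in size. Going by the values given here, the step to compound 2 is therefore the only one bearing on this change, and it was modest. A comparable small rise in this assay is expected for compound 3, given as a number 8.9 percentage points higher from compound 1 to compound 3 (within the scatter). The estimate for compound 3 in this assay is 7%, with a range from -8% to 22%.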

Compound 3, a percentage reported as inhibition, at one concentration (the size of the read-out at that concentration, not a potency): -9.5%
The estimate for compound 3 lay 16.5 percentage points above the measured number; measured number below the stated range.
By their numbers in this assay, from the lowest: compounds 3 and 1 (each within the scatter of the next); then compound 2.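

The 5-hydroxy-2H-1,2,3-triazol-4-yl group on the carbonyl carbon does not separate from the sulfur-bearing ring of compound 1, with a number 7.6 percentage points lower from compound 1 to compound 3 (within the scatter), so a hydroxy-bearing ring with three hetero atoms does not by itself carry the rise seen earlier. The step that does show a difference is hydrogen in place of methyl on an aromatic nitrogen, a number 18.6 percentage points lower from compound 2 to compound 3 (beyond the scatter), which ties the higher number among these compounds to that methyl, though compound 2 is the only compound carrying it. No measurement is available that would explain this difference.

Still open, on these data alone, is whether an ethyl group or a longer chain on that aromatic nitrogen, or an amine or a carboxylic acid in place of the hydroxy group, would move the number further. Among the compounds shown here, also open is whether this series can reach clear inhibition of the kinase, since the highest number so far is the one for compound 2, 9.1%, and a single-concentration read-out of this size gives no potency.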